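Aminoquinoline Ethers: Replacing Cyclopentyl with Oxolanyl

The source may report more compounds than this note shows. Statements on the series, on what has been measured and on what is new or still open speak of the compounds shown alone.

Measured compounds:
compound 1 `Nc1ccc2cccc(OCC3CCCC3)c2n1`, 2290 nM
compound 2 `Nc1ccc2cccc(OC3CCCCCC3)c2n1`, 3480 nM
compound 3 `CC(CC(C)(C)C)Oc1cccc2ccc(N3CCCCC3)nc12`, value given as a limit

In a functional assay on IMR-32 cells with melanin-concentrating hormone receptor 1 (Homo sapiens) as the target, read by fluorescence (a higher number here means a weaker inhibitor, a lower number a stronger inhibitor), compound 1 gives 2290 nM, the lower of the two numbers shown, with compound 2 at 3480 nM lying within the scatter of it, so no order between the two can be read. For compound 3 the assay reports only a limit, > 10000 nM, not a number (the limit of > 10000 nM in this assay, at which 1 of the 3 values shown sits). Compound 4 `Nc1ccc2cccc(OCC3CCOC3)c2n1` differs from compound 1 by oxolan-3-yl in place of cyclopentyl on a saturated chain carbon bound to an oxygen on an aromatic ring. Going by the values given here, no pair of measured compounds differing in one place is available to size this kind of change, so the expectation rests on the value of compound 1 alone. Compound 4 is expected to give a somewhat higher number, with the step from a 1.7-fold higher number from compound 1 to compound 4 (0.24 log units; within the scatter) estimated as modest and uncertain in sign. Compound 4 is thus estimated at 4000 nM, within 1500 nM to 12000 nM.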

Compound 4, half-maximal inhibitory concentration: 6240 nM
Compound 4: middle estimate off by 1.6-fold (0.19 log units), on the low side, within the range that was stated.
By their numbers in this assay, from the lowest: compounds 1, 2 and 4 (each within the scatter of the next, the first and the last beyond it). At a limit, above all of these: compound 3.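

Oxolan-3-yl in place of cyclopentyl on a saturated chain carbon bound to an oxygen on an aromatic ring gives a 2.7-fold higher number from compound 1 to compound 4 (0.44 log units; beyond the scatter) in this assay and so provides the first sized step at this place. The two groups differ only in one ring carbon giving way to oxygen, so this place does not treat these two five-membered rings alike. Nothing measured here accounts for the step.

From the compounds shown here alone, what oxolan-2-yl, pyrrolidin-3-yl or a longer chain would do at this place remains open. Also open, going by these compounds, is whether the same ring change would have a similar effect on the seven-membered ring of compound 2.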